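Changing the aromatic group on the ring amine nitrogen

This account rests on a few compounds, and the source may have more. Where it says the series, first, only, none or still open, it means among the compounds named here.

Compound 2 `CCCc1nc(-c2ccccc2)c(CNCCCN2CCN(c3cccc(C)c3C)CC2)o1` stands higher of the two measured compounds in an assay on HEK293 cells for inhibition of Voltage-dependent T-type calcium channel subunit alpha-1G (Homo sapiens), read by fluorescence, tested at 10 uM; on this read-out lower numbers stand for less inhibition and higher numbers for more inhibition at the one concentration tested (going by the name of the read-out): compound 2 gives 55.2%, while compound 1 `CCCc1nc(-c2ccccc2)c(CNCCCN2CCN(c3ccccc3C(F)(F)F)CC2)o1` gives 45%. Among the measured compounds shown here, the only measured step, a number 10.2 percentage points higher from compound 1 to compound 2 (beyond the scatter), shows that exchanging the aromatic group on the amine nitrogen in the ring can shift the read-out by a modest amount. Compound 3 `CCCc1nc(-c2ccccc2)c(CNCCCN2CCN(c3ccc(Cl)cc3)CC2)o1` differs from compound 2 at the same place: 4-chlorophenyl in place of 2,3-dimethylphenyl on an amine nitrogen in a ring. For the measured compounds named here, no measured pair contains a 4-chlorophenyl at this position, so the direction of the step cannot be read from the data, and the one related step only suggests that such swaps move the number modestly. Compound 3 is therefore expected to land near the two measured values, with an estimated step of a number 10.2 percentage points lower from compound 2 to compound 3 (beyond the scatter). The estimate for compound 3 in this assay is 45%, within a range from 25% to 65%.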

Compound 3, a percentage reported as inhibition, at one concentration (the size of the read-out at that concentration, not a potency): 63.3%
Beside the measured number, compound 3's estimate is 18.3 percentage points below it, and the stated range covers the measured number.
By their numbers in this assay, from the lowest: compound 1; then compounds 2 and 3 (each within the scatter of the next).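

In this assay, replacing 2,3-dimethylphenyl with 4-chlorophenyl gives a number 8.1 percentage points higher from compound 2 to compound 3 (within the scatter), so this position accepts either group without a difference that can be read, even though the two rings carry different substituents at different places. Among the compounds shown here, the other swap gives a number 18.3 percentage points higher from compound 1 to compound 3 (beyond the scatter), and together with the earlier step this sets compound 1, with its 2-(trifluoromethyl)phenyl group, lowest of the three, the only group here that stands apart from the others. No measurement at hand explains why the 2-(trifluoromethyl)phenyl group stands apart.

The compounds shown leave open whether moving the chlorine matters, as 2-chlorophenyl and 3-chlorophenyl groups are not among them. On these data alone, how an unsubstituted phenyl or a pyridyl ring on this nitrogen would read also remains unknown.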